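A Smaller Amide Substituent: From Compound 3 to Compound 4

The source may report more compounds than this note shows. Statements on the series, on what has been measured and on what is new or still open speak of the compounds shown alone.

Of the compounds shown here, three sharing one core have been tested in a functional assay on SU-DHL-6 cells (Homo sapiens) for antiproliferative activity, read by MTT assay; a lower number here means a stronger inhibitor, a higher number a weaker inhibitor. Compound 1 `COc1ncc(-c2ccc3ncnc(N[C@H]4CCCN(C(=O)CN(C)C)C4)c3c2)cc1C#N` gives 160 nM, compound 2 `CCOC(=O)CN1CCC[C@H](Nc2ncnc3ccc(-c4cnc(OC)c(C(F)(F)F)c4)cc23)C1` gives 230 nM, and compound 3 `COc1ncc(-c2ccc3ncnc(N[C@H]4CCCN(C(=O)C5CCOCC5)C4)c3c2)cc1C#N` gives 150 nM, the lowest of the three numbers, though each gap lies within the usual scatter. Going by the values given here, the single one-place step measured so far, a 1.1-fold lower number from compound 1 to compound 3 (0.03 log units; within the scatter), changed nothing beyond the scatter. Compound 4 `COc1ncc(-c2ccc3ncnc(N[C@H]4CCCN(C(=O)C(C)N)C4)c3c2)cc1C#N` carries a further change on the carbonyl carbon: 1-aminoethyl in place of oxan-4-yl on a carbonyl carbon. Among the compounds with values here, only that earlier step bears on it, and it was small, so in this assay no shift beyond the scatter is expected. The expected step is a 1.1-fold higher number from compound 3 to compound 4 (0.03 log units; within the scatter). Compound 4 is therefore estimated to give about 160 nM, with a range from 70 nM to 400 nM.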

Compound 4, half-maximal inhibitory concentration: 440 nM
Compound 4: the middle estimate sits 2.8-fold (0.44 log units) below what was measured; the whole stated range lies below it.
By their numbers in this assay, from the lowest: compounds 3, 1, 2 and 4 (each within the scatter of the next, the first and the last beyond it).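

In this assay, the group on this carbonyl carbon does matter: 1-aminoethyl gives a 2.9-fold higher number from compound 3 to compound 4 (0.47 log units; beyond the scatter) and also a 2.8-fold higher number from compound 1 to compound 4 (0.44 log units; beyond the scatter) while oxan-4-yl and (dimethylamino)methyl stayed within the scatter of each other. So this position tolerates some changes of group but not every one. Nothing available explains the rise in the number.

As far as these compounds go, whether the amine or the loss of the ring goes with the change stays open. A plain ethyl group on the same carbonyl carbon, carrying no amine, would help separate the two.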